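The source may report more compounds than this note shows. Statements on the series, on what has been measured and on what is new or still open speak of the compounds shown alone.

Measured compounds: compound 1 `COc1ccc(CNc2cc(OC)c(OC)c(OC)c2)cc1Br`, 48100 nM; compound 2 `COc1ccc(CNc2cc(OC)c(OC)c(OC)c2)cc1`, 18400 nM; compound 3 `COc1ccc(CNc2cc(OC)c(OC)c(OC)c2)cc1N`, 8270 nM.

In a functional assay on HCT-116 cells (Homo sapiens) for inhibition, read by MTT assay, with a stated time of 48 h (a higher number here means a weaker inhibitor, a lower number a stronger inhibitor), compound 2 stands second highest of the three numbers, with compound 3 nearest a 2.2-fold lower number from compound 2 to compound 3 (0.35 log units; beyond the scatter) and compound 1 furthest a 2.6-fold lower number from compound 1 to compound 2 (0.42 log units; beyond the scatter). Compound 4 `COc1cc(NCc2ccc(Br)cc2)cc(OC)c1OC` differs from compound 2 by bromo in place of methoxy on an aromatic carbon. Among the measured compounds shown here, no measured step changes this position; the only step with bromo is a 5.8-fold lower number from compound 1 to compound 3 (0.76 log units; beyond the scatter) and a 2.6-fold lower number from compound 1 to compound 2 (0.42 log units; beyond the scatter), where bromo entering at another carbon went with a higher number. A modest rise is therefore expected, a 1.5-fold higher number from compound 2 to compound 4 (0.18 log units; within the scatter), and compound 4 is estimated at 28000 nM, within 9000 nM to 85000 nM.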

Compound 4, half-maximal inhibitory concentration: > 80000 nM
Compound 4 ended at the assay's limit; the forecaster's own chance of this, stated with the estimate: 10%; at least 2.8-fold (0.45 log units) between middle value and limit.
By their numbers in this assay, from the lowest: compound 3; then compound 2; then compound 1. At a limit, above all of these: compound 4.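

In this assay compound 4 gives > 80000 nM, which is a limit of the assay and not a number. Bromo in place of methoxy, para to a large group, gives an at least 4.3-fold higher number from compound 2 to compound 4 (0.63 log units; beyond the scatter). Among the compounds shown here, the earlier steps all changed another carbon, so this is the first reading of this position, and it shows that the number here responds to a change at this carbon.

The compounds shown leave open whether the rise goes with losing methoxy or with gaining bromo. A hydroxy group, an ethoxy group or an amine at this carbon could separate the two.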